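This account rests on a few compounds, and the source may have more. Where it says the series, first, only, none or still open, it means among the compounds named here.

Going by the values given here, compound 1, with the structure `CC(=O)OC[C@H]1O[C@@H](n2cc(CN(c3ccccc3)S(=O)(=O)c3ccccc3)nn2)[C@H](OC(C)=O)[C@@H]1OC(C)=O`, is one of three compounds measured in a functional assay on MDA-MB-231 cells (Homo sapiens) for antiproliferative activity, read by XTT assay, with a stated time of 48 h (a lower number here means a stronger inhibitor, a higher number a weaker inhibitor), where compound 1 gives 100000 nM. Compound 2, with the structure `CC(=O)OC[C@H]1O[C@@H](n2cc(CN(c3ccc(Cl)cc3)S(=O)(=O)c3ccccc3)nn2)[C@H](OC(C)=O)[C@@H]1OC(C)=O`, differs from compound 1 by the change (chloro in place of hydrogen on an aromatic carbon), and in this assay compound 2 gives 250000 nM. That single change made a step of a 2.5-fold higher number from compound 1 to compound 2 (0.40 log units; beyond the scatter).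

Compound 3, with the structure `CCS(=O)(=O)N(Cc1cn([C@@H]2O[C@H](COC(C)=O)[C@@H](OC(C)=O)[C@H](OC(C)=O)[C@H]2OC(C)=O)nn1)c1ccccc1`, carries a different core; the difference between the core of compound 1 and the core of compound 3 is not broken down here. In this assay compound 3 gives 155000 nM, a number that lies within the scatter of compound 1 and within the scatter of compound 2.

Compound 4, with the structure `CCS(=O)(=O)N(Cc1cn([C@@H]2O[C@H](COC(C)=O)[C@@H](OC(C)=O)[C@H](OC(C)=O)[C@H]2OC(C)=O)nn1)c1ccc(Cl)cc1`, has not yet been measured. It differs from compound 3 by the change (chloro in place of hydrogen on an aromatic carbon), the same kind of change that was made from compound 1 to compound 2, and the two places are described in the same words. Compound 4 is therefore expected to follow the same direction as the earlier step, and its estimated step is a 2.5-fold higher number from compound 3 to compound 4 (0.39 log units; beyond the scatter), a size that rests on the step of a 2.5-fold higher number from compound 1 to compound 2 (0.40 log units; beyond the scatter) seen on the other core. On that basis compound 4 is estimated to give 380000 nM in this assay, with an expected range from 150000 nM to 900000 nM.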

Compound 4, half-maximal inhibitory concentration: > 250000 nM
Compound 4: only a limit was reported; the forecaster's own chance of this, stated with the estimate: 30%; the middle value is on the limit's open side.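

In this assay compound 4 gives > 250000 nM, which is a limit of the assay and not a number. Putting 4-chlorophenyl in place of phenyl on the core of compound 3 gives an at least 1.6-fold higher number from compound 3 to compound 4 (0.20 log units; that floor lies within the scatter), so the result fits a step in the same direction as on the core of compound 1, but its floor alone does not establish a rise beyond the scatter. The two cores therefore show no conflict, yet they also do not show that the change carries over with the same size, and the comparison stops at what the limit allows: the same change on two cores in this assay, a 2.5-fold higher number (0.40 log units; beyond the scatter) from compound 1 to compound 2 and an at least 1.6-fold higher number (0.20 log units; that floor lies within the scatter) from compound 3 to compound 4; the limit leaves it open whether they differ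

All the compounds shown carry only hydrogen or chloro on that aromatic ring, so it remains open how a fluoro, a methoxy or an amine at the same place would read in this assay, and whether any of them would give a lower number than compound 1. Also open, on these data alone, is what a free hydroxyl in place of the acetyl esters would do, or a longer chain on the sulfonyl group in place of the ethyl of compound 3.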